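Thiazole Swap on a Shared Macrocyclic Core: Tolerated Concentration

The source may hold more compounds than are shown below. What is called first, only, known or untested is meant among the compounds shown, and "the series" means these compounds.

Compound 1 `COc1ccc2c(O[C@H]3C[C@H]4C(=O)N(C)CCCC/C=C/[C@@H]5C[C@@]5(C(=O)NS(=O)(=O)C5CC5)NC(=O)N4C3)cc(-c3csc(C(F)(F)F)n3)nc2c1C`: 75000 nM in an ADME assay on Huh-7 cells (Homo sapiens) for cytotoxicity, read by colorimetric assay; a lower number here means that less compound is tolerated, a higher number that more compound is tolerated
Compound 2 `COc1ccc2c(O[C@H]3C[C@H]4C(=O)N(C)CCCC/C=C/[C@@H]5C[C@@]5(C(=O)NS(=O)(=O)C5(C)CC5)NC(=O)N4C3)cc(-n3cc(C(C)C)cn3)nc2c1C`: 9610 nM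
Compound 3 `COc1ccc2c(O[C@H]3C[C@H]4C(=O)N(C)CCCC/C=C/[C@@H]5C[C@@]5(C(=O)NS(=O)(=O)C5(C)CC5)NC(=O)N4C3)cc(C#N)nc2c1C`: 55800 nM

Compound 1 gives the highest of the three numbers in this assay; compound 3 lies within the scatter of it, while compound 2 sits beyond the scatter below it. Compound 4 `C#Cc1csc(-c2cc(O[C@H]3C[C@H]4C(=O)N(C)CCCC/C=C/[C@@H]5C[C@@]5(C(=O)NS(=O)(=O)C5CC5)NC(=O)N4C3)c3ccc(OC)c(C)c3n2)n1` carries 4-ethynyl-1,3-thiazol-2-yl in place of 2-(trifluoromethyl)-1,3-thiazol-4-yl on an aromatic carbon. Going by the values given here, the one measured step at that carbon, a 5.8-fold higher number from compound 2 to compound 3 (0.76 log units; beyond the scatter), traded a pyrazolyl for a cyano and moved the number only modestly; no measured pair compares two thiazolyls. Since one thiazolyl replaces another, the change is expected to be small, and compound 4 is expected to stay near compound 1, with a 1.5-fold lower number from compound 1 to compound 4 (0.18 log units; within the scatter) not beyond the scatter. The estimated value for compound 4 is 50000 nM, within a range of 20000 nM to 120000 nM.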

Compound 4, half-maximal cytotoxic concentration: 14400 nM
The estimate for compound 4 lay 3.5-fold (0.54 log units) above the measured number; the measured number lies below the stated range.
By their numbers in this assay, from the lowest: compounds 2 and 4 (each within the scatter of the next); then compounds 3 and 1 (each within the scatter of the next).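

In this assay, exchanging one thiazolyl for another at this aromatic carbon is not a silent change: there is a 5.2-fold lower number from compound 1 to compound 4 (0.72 log units; beyond the scatter) on going to 4-ethynyl-1,3-thiazol-2-yl. The position therefore responds even when the entering and leaving groups each hold a five-membered aromatic ring with the same count of hetero atoms. No measurement available here explains this shift. Still open, going by these compounds, is whether the loss of trifluoromethyl, the arrival of ethynyl or the different attachment of the thiazole carries the step, and where a thiazolyl bearing an amine would fall.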